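Swapping the aryl group of compound 2 for 3-aminophenyl

The source may report more compounds than this note shows. Statements on the series, on what has been measured and on what is new or still open speak of the compounds shown alone.

Three compounds have been measured in a functional assay on MCF7 cells (Homo sapiens) for antiproliferative activity, read by MTT assay, with stated times of 24 h and 72 h; a lower number here means a stronger inhibitor, a higher number a weaker inhibitor:
compound 1 `COc1cc(N2C(=O)[C@@H](Oc3ccccc3)[C@H]2c2ccc3ccccc3c2)cc(OC)c1OC` gives 282000 nM
compound 2 `COc1cc(N2C(=O)[C@@H](Oc3ccccc3)[C@H]2c2ccc(SC)cc2)cc(OC)c1OC` gives 7700 nM
compound 3 `CCOC(=O)/C=C/c1ccc([C@@H]2[C@H](Oc3ccccc3)C(=O)N2c2cc(OC)c(OC)c(OC)c2)cc1` gives 87000 nM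

Compound 2 stands lowest of the three: a 37-fold lower number from compound 1 to compound 2 (1.56 log units; beyond the scatter), and an 11-fold higher number from compound 2 to compound 3 (1.05 log units; beyond the scatter). Compound 4 `COc1cc(N2C(=O)[C@@H](Oc3ccccc3)[C@H]2c2cccc(N)c2)cc(OC)c1OC` differs from compound 2 by 3-aminophenyl in place of 4-(methylsulfanyl)phenyl on a saturated ring carbon. Among the compounds with values here, both measured steps alter the group carried by that saturated ring carbon, and both were large, so the aryl group clearly matters; the entering 3-aminophenyl group, however, has no measured counterpart, and the direction of the step cannot be read from the data. For compound 4 the estimate is 15000 nM, within 3000 nM to 80000 nM, which corresponds to an expected step of a 1.9-fold higher number from compound 2 to compound 4 (0.29 log units; within the scatter).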

Compound 4, half-maximal inhibitory concentration: 17000 nM
The estimate for compound 4 lay 1.1-fold (0.05 log units) below the measured number; the measured number falls inside the stated range.
By their numbers in this assay, from the lowest: compound 2; then compound 4; then compound 3; then compound 1.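

In this assay, putting 3-aminophenyl on the saturated ring carbon in place of 4-(methylsulfanyl)phenyl gives only a modest loss, a 2.2-fold higher number from compound 2 to compound 4 (0.34 log units; beyond the scatter), while the same group in place of naphthalen-2-yl gives a large gain, a 17-fold lower number from compound 1 to compound 4 (1.22 log units; beyond the scatter). This position therefore accepts an aryl group bearing a hydrogen-bond donor and no sulfur at a modest cost relative to compound 2. No measured evidence explains either step. From the compounds shown here alone, how a hydroxyl or a carboxylic acid in place of the amine would compare remains open.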